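The compounds below may be only part of what the source reports. "The series", "measured", "known", "first", "only" and "open" are said of these compounds alone.

In an assay on isolated protein for inhibition of Aromatase (Homo sapiens), read by fluorescence, tested at 1 uM (on this read-out lower numbers stand for less inhibition and higher numbers for more inhibition at the one concentration tested (going by the name of the read-out)), compound 3 `N#Cc1ccc(Oc2cccnc2)c(Oc2cccnc2)c1` gives 82%, the highest of the three numbers in hand. Compound 1 `N#Cc1ccc(Oc2cccnc2)cc1NC1CCCCC1` gives 33% and compound 2 `N#Cc1ccc(Oc2cccnc2)cc1Oc1cccc(Cl)c1` gives 25%, both beyond the scatter below compound 3. Within the data shown here, no pair of measured compounds differs in a single place, so no measured step guides the next change. Compound 4 `N#Cc1ccc(Oc2cccnc2)c(F)c1` differs from compound 3 by fluoro in place of (pyridin-3-yl)oxy on an aromatic carbon. Against compound 3, which gives 82%, a fall beyond the scatter is expected, since compound 1 at 33% and compound 2 at 25% show lower numbers with other replacements of one (pyridin-3-yl)oxy group. Compound 4 is expected to give 40%, with a range from 15% to 70%. The expected step is a number 42 percentage points lower from compound 3 to compound 4 (beyond the scatter).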

Compound 4, a percentage reported as inhibition, at one concentration (the size of the read-out at that concentration, not a potency): 52%
The estimate for compound 4 lay 12 percentage points below the measured number; low and high end bracket the measured number.
By their numbers in this assay, from the lowest: compounds 2 and 1 (each within the scatter of the next); then compound 4; then compound 3.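

In this assay, among these compounds, the first single-place comparison is a number 30 percentage points lower from compound 3 to compound 4 (beyond the scatter), so at this aromatic carbon, fluoro in place of (pyridin-3-yl)oxy lowers inhibition. Even so, compound 4 keeps 52% with only fluoro there, so the (pyridin-3-yl)oxy group at this carbon is not required for all of the inhibition seen. Nothing in hand accounts for the size of this step.

Still open, as far as these compounds go, is whether a methoxy group or a plain phenoxy group at this carbon would read closer to compound 3 or compound 4.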